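This account rests on a few compounds, and the source may have more. Where it says the series, first, only, none or still open, it means among the compounds named here.

Measured compounds in an assay on HEK293 cells for displacement of a labelled ligand from Melanocortin receptor 4 (Homo sapiens); on this read-out lower numbers stand for stronger inhibition and higher numbers for weaker inhibition:
compound 1 `Cc1cc(Cl)ccc1CC(C)C(=O)N1CCN(c2ccc(C(F)(F)F)cc2[C@@H](N)CC(C)C)CC1` — 38 nM
compound 2 `Cc1cc(CC(C)C(=O)N2CCN(c3ccc(C(F)(F)F)cc3[C@@H](N)CC(C)C)CC2)ccc1Cl` — 71 nM
compound 3 `CC(C)C[C@H](N)c1cc(C(F)(F)F)ccc1N1CCN(C(=O)CCC(=O)N(C)C)CC1` — > 10000 nM, which is a limit of the assay and not a number

Compound 3 thus sits at the limit of > 10000 nM in this assay, at which 1 of the 3 values shown sits, the weak end of the values shown. Compound 4 `CC(C)C[C@H](N)c1cc(C(F)(F)F)ccc1N1CCN(C(=O)CCNC2CCCCC2)CC1` differs from it by cyclohexylamino in place of dimethylcarbamoyl on a saturated chain carbon, two bonds along the chain from a carbonyl carbon. For the measured compounds named here, no measured step touches a cyclohexylamino group. Going by the values given here, the steps that bear on this end of the molecule are an at least 260-fold higher number from compound 1 to compound 3 (2.42 log units; beyond the scatter) and an at least 140-fold higher number from compound 2 to compound 3 (2.14 log units; beyond the scatter), both large, showing that the group on this carbonyl carbon moves the number strongly. Because compound 3 is only a limit, the direction that is open is downward, and a moderate improvement is expected but far from certain. The estimate for compound 4 is 3000 nM, in the range 400 nM to 20000 nM, which means an expected step of an at least 3.3-fold lower number from compound 3 to compound 4 (0.52 log units; beyond the scatter).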

Compound 4, inhibition constant: 4800 nM
Beside the measured number, compound 4's estimate is 1.6-fold (0.20 log units) below it, within the range that was stated.
By their numbers in this assay, from the lowest: compounds 1 and 2 (each within the scatter of the next); then compound 4. At a limit, above all of these: compound 3.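

In this assay, for the compounds shown here, cyclohexylamino in place of dimethylcarbamoyl gives the first measured number for a chain of this kind (an at least 2.0-fold lower number from compound 3 to compound 4 (0.31 log units; beyond the scatter)). As far as these compounds go, the value of compound 3 is a limit of the assay and not a number, so the true size of this step stays unknown: (the limit of > 10000 nM in this assay, at which 1 of the 4 values shown sits). The 2-(cyclohexylamino)ethyl chain still falls well short of the benzyl-bearing groups (a 68-fold higher number from compound 2 to compound 4 (1.83 log units; beyond the scatter); a 130-fold higher number from compound 1 to compound 4 (2.10 log units; beyond the scatter)).

From the compounds shown here alone, it remains open whether the ring or the amine drives this change. A dimethylamino group or a phenyl ring at this chain carbon would separate the two.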